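From a chlorobenzyl amide back to the free acid

The compounds below may be only part of what the source reports. "The series", "measured", "known", "first", "only" and "open" are said of these compounds alone.

The three compounds measured so far share one core, shown in compound 1 `C=CC1=C(C(=O)O)C(c2ccc(OC)cc2)OC1` as a free acid bearing a methoxyphenyl group. In a functional assay on QGY7701 cells (Homo sapiens) for cytotoxicity, read by MTT assay, with a stated time of 24 h (on this read-out lower numbers stand for stronger inhibition and higher numbers for weaker inhibition), compound 1 sits at the limit of the assay, > 100000 nM. Compound 2 `C=CC1=C(C(=O)NCc2ccc(C)cc2)C(c2ccc(OC)c(OC)c2)OC1` carries a dimethoxyphenyl group and an amide in place of the acid; in this assay compound 2 gives 69100 nM. Compound 3 `C=CC1=C(C(=O)NCc2ccc(Cl)cc2)C(c2ccc(OC)c(OC)c2)OC1` differs from compound 2 only by chloro in place of methyl on an aromatic carbon. In this assay compound 3 again sits at the limit, > 100000 nM. The step of an at least 1.4-fold higher number from compound 2 to compound 3 (0.16 log units; that floor lies within the scatter) is thus only a floor, and compound 3 stands with compound 1 at the limit of > 100000 nM in this assay, at which 2 of the 3 values shown sit.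

Compound 4 `C=CC1=C(C(=O)O)C(c2ccc(OC)c(OC)c2)OC1` is reached from compound 3 by hydroxy in place of (4-chlorobenzyl)amino on a carbonyl carbon: the amide is opened to the free acid while the dimethoxyphenyl group is kept. For the measured compounds named here, no measured step removes the amide. The only free acid measured, compound 1, returned a limit in this assay. Compound 3 itself returned a limit as well. With no number at either end of the change, the author expects the step that the limit leaves unreadable from compound 3 to compound 4 to stay within the scatter, with compound 4 most likely reported again as a limit. The estimate for compound 4 in this assay is 150000 nM, ranging from 70000 nM to 400000 nM.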

Compound 4, half-maximal inhibitory concentration: > 100000 nM
Compound 4 was reported as a limit; the forecaster's own chance of this, stated with the estimate: 85%; the middle value lies beyond the limit too.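

Compound 4 adds a second free acid to the set, and in this assay its result is again a limit, as it is for compound 1 and compound 3; the steps among these three compounds cannot be read. For the compounds shown here, the one readable change at this position is an at least 1.4-fold higher number from compound 2 to compound 4 (0.16 log units; that floor lies within the scatter), so exchanging (4-methylbenzyl)amino for hydroxy on the carbonyl carbon yields only a floor, and that floor does not separate the two compounds. Compound 2 therefore remains the only compound here with a number rather than a limit, while hydroxy now joins (4-chlorobenzyl)amino on the carbonyl carbon in a single group of results: the limit of > 100000 nM in this assay, at which 3 of the 4 values shown sit.

From the compounds shown here alone, how far compound 1, compound 3 and compound 4 actually lie beyond the limit stays unknown, so nothing ranks the free acids against the chlorobenzyl amide. Going by these compounds, whether an unsubstituted benzylamino group, a 4-methoxybenzylamino group or a methyl ester on the same carbonyl carbon would give a number rather than a limit also remains open.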